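Benzyl for cyclohexyl on the imidazole nitrogen of two cores

The source may hold more compounds than are shown below. What is called first, only, known or untested is meant among the compounds shown, and "the series" means these compounds.

Measured compounds:
compound 1 `O=Cc1ccc(-c2cn3ccnc3c(-c3ccc4ncn(C5CCCCC5)c4c3)n2)cc1` — 46.7%
compound 2 `O=Cc1ccc(-c2cn3ccnc3c(-c3ccc4ncn(Cc5ccccc5)c4c3)n2)cc1` — 46.7%
compound 3 `c1cn2cc(-c3ccc4c(c3)ncn4C3CCCCC3)nc(-c3ccc4ncn(C5CCCCC5)c4c3)c2n1` — 25.8%

In a functional assay on 786-0 cells (Homo sapiens) for inhibition, read by sulforhodamine B assay, with a stated time of 48 h, tested at 10 uM (on this read-out higher numbers stand for more inhibition at the one concentration tested (going by the name of the read-out) and lower numbers for less inhibition), compound 1 gives 46.7% and compound 2 gives 46.7%. The two share a core and differ in one place, (benzyl in place of cyclohexyl on an aromatic nitrogen), and the step of no change at the digits printed from compound 1 to compound 2 (within the scatter) shows that this exchange leaves the read-out where it was. Compound 3 carries a different core; the difference between the core of compound 1 and the core of compound 3 is not broken down here. In this assay compound 3 gives 25.8%, the lowest of the three numbers and beyond the scatter from both others.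

Compound 4 `c1ccc(Cn2cnc3ccc(-c4nc(-c5ccc6c(c5)ncn6C5CCCCC5)cn5ccnc45)cc32)cc1` has not yet been measured. It stands to compound 3 as compound 2 stands to compound 1: benzyl in place of cyclohexyl on an aromatic nitrogen. The place lines of the two exchanges are the same word for word, so this is the same change made on the other core. Among the compounds with values here, the only information about the size of its step comes from the one measured example, no change at the digits printed from compound 1 to compound 2 (within the scatter), which is within the scatter.

The expectation is therefore that the step of a number 0.2 percentage points higher from compound 3 to compound 4 (within the scatter) stays small, because compound 1 to compound 2 gave no change at the digits printed from compound 1 to compound 2 (within the scatter). On that basis compound 4 is estimated at 26% in this assay, with a range from 12% to 42%. From the compounds shown here alone, whether the core of compound 3 responds in the same way as the core of compound 1 is untested; one measured pair is the whole of the evidence.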

Compound 4, a percentage reported as inhibition, at one concentration (the size of the read-out at that concentration, not a potency): -19.4%
Estimate against measurement, compound 4: 45.4 percentage points above; the whole stated range lies above it.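

In this assay, benzyl in place of cyclohexyl on an aromatic nitrogen does not behave as one transferable exchange across the two cores, as the two measured pairs disagree: the same change on two cores in this assay, no change at the digits printed (within the scatter) from compound 1 to compound 2 and a number 45.2 percentage points lower (beyond the scatter) from compound 3 to compound 4, 45.2 percentage points apart, beyond the scatter of two such steps. On the core of compound 3 the exchange gives a number 45.2 percentage points lower from compound 3 to compound 4 (beyond the scatter), so the flat result on the core of compound 1 cannot be used to predict the outcome on another core in this series. Within the data shown here, this does not show why the cores part ways, nor which core would be the typical case, as there are only two pairs, each read at a single concentration, and the size of the step on any third core remains unknown.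

Still open, from the compounds shown here alone, is whether the large step on the core of compound 3 is specific to benzyl or would also appear with other groups on that aromatic nitrogen, such as a longer alkyl chain or a chain ending in an amine. Also open, going by these compounds, is how a carboxylic acid in place of the aldehyde carbonyl of compound 1 and compound 2 would read, and whether the exchange would then stay as flat as it does on that core.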